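This account rests on a few compounds, and the source may have more. Where it says the series, first, only, none or still open, it means among the compounds named here.

Series in a functional assay on HCT-116 cells (Homo sapiens), read by MTT assay, with a stated time of 72 h; a lower number here means a stronger inhibitor, a higher number a weaker inhibitor:
Compound 1 `COc1ncnc2c1c(-c1cc3ccccc3o1)cn2[C@@H]1O[C@H](CO)[C@@H](O)[C@H]1O`: 13800 nM
Compound 2 `CNc1ncnc2c1c(-c1cc3ccccc3o1)cn2[C@@H]1O[C@H](CO)[C@@H](O)[C@H]1O`: > 20000 nM, a limit
Compound 3 `Cc1ncnc2c1c(-c1cc3ccccc3o1)cn2[C@@H]1O[C@H](CO)[C@@H](O)[C@H]1O`: > 20000 nM, a limit
Compound 4 `COc1nc(N)nc2c1c(-c1cc3ccccc3o1)cn2[C@@H]1O[C@H](CO)[C@@H](O)[C@H]1O`: not yet measured

Going by the values given here, compound 1 holds the only number in this assay. The rest of the series stands at the limit of > 20000 nM in this assay, at which 2 of the 3 values shown sit.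

Compound 4 differs from compound 1 by amino in place of hydrogen on an aromatic carbon, between two ring nitrogen atoms. Among the compounds with values here, no measured step changes that carbon. The nearest are an at least 1.4-fold higher number from compound 1 to compound 2 (0.16 log units; that floor lies within the scatter) and an at least 1.4-fold higher number from compound 1 to compound 3 (0.16 log units; that floor lies within the scatter), and both replace the methoxy group that compound 4 keeps. They give only indirect guidance, so no shift beyond the scatter is expected, in either direction. The expected step is a 1.2-fold higher number from compound 1 to compound 4 (0.06 log units; within the scatter). For compound 4 the estimated value is 16000 nM, with an expected range of 6000 nM to 35000 nM.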

Compound 4, half-maximal inhibitory concentration: > 20000 nM
Compound 4: no number, only a limit; the forecaster's own chance of this, stated with the estimate: 45%; middle value at least 1.2-fold (0.09 log units) away from the limit.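

Amino in place of hydrogen on the aromatic carbon between two ring nitrogen atoms is the only change shown at this position, and the methoxy group stays in place. In this assay compound 4 gives > 20000 nM as a limit, not a number. The step reads an at least 1.4-fold higher number from compound 1 to compound 4 (0.16 log units; that floor lies within the scatter) and shows no gain from amino at this carbon, while a real loss is not established, and the series now sits mostly at one value: the limit of > 20000 nM in this assay, at which 3 of the 4 values shown sit.

On these data alone, whether fluorine or a dimethylamino group at this carbon would give a number in this assay stays open.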